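The source may hold more compounds than are shown below. What is called first, only, known or untested is meant among the compounds shown, and "the series" means these compounds.

The measured compounds:
Compound 1, `COc1ccc(C2N=C(SCc3ccccc3)NC(C)=C2C(=O)Nc2ccc(F)cc2)cc1OC`, in a functional assay on the whole organism (artery, strain albino) with Rattus norvegicus as the target, with a stated time of 240 min, at a dose of 10 mg/kg by the oral route (a lower number here means less inhibition, a higher number more inhibition at the dose given (going by the name of the read-out)), compound 1 gives 11.8%.
Compound 2, `COc1ccc(C2N=C(SCc3ccccc3Cl)NC(C)=C2C(=O)Nc2ccc(F)cc2)cc1OC`, compound 2 gives 30.3%.
Compound 3, `COc1ccc(C2N=C(SCc3ccc(Cl)cc3)NC(C)=C2C(=O)Nc2ccc(F)cc2)cc1OC`, compound 3 gives 24.1%.

Compound 1 stands lowest of the three numbers. Its nearest neighbour is compound 3, a step of a number 12.3 percentage points higher from compound 1 to compound 3 (beyond the scatter), and the furthest is compound 2, a step of a number 18.5 percentage points higher from compound 1 to compound 2 (beyond the scatter). The two chlorinated compounds differ from each other by a number 6.2 percentage points lower from compound 2 to compound 3 (within the scatter).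

Compound 4, `CC1=C(C(=O)Nc2ccc(F)cc2)C(c2ccc([N+](=O)[O-])cc2)N=C(SCc2ccccc2)N1`, has not yet been measured. It differs from compound 1 in one place: 4-nitrophenyl in place of 3,4-dimethoxyphenyl on a saturated ring carbon. Both measured steps concern chloro in place of hydrogen on an aromatic carbon of the benzylsulfanyl group, and neither touches the group on the saturated ring carbon of the shared core. Among the measured compounds shown here, no measured step therefore bears on this change, and the data give no direction for it. The expectation is a number near that of compound 1, with a wide range to allow for the unknown.

Compound 4 is expected to give about 15% in this assay. For compound 4 the expected range is from 0% to 40%. For compound 4 this estimate means an expected step of a number 3.2 percentage points higher from compound 1 to compound 4 (within the scatter).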

Compound 4, a percentage reported as inhibition, in the whole organism at one dose (the size of the read-out at that dose, not a potency): 32.3%
Beside the measured number, compound 4's estimate is 17.3 percentage points below it; low and high end bracket the measured number.
By their numbers in this assay, from the lowest: compound 1; then compounds 3, 2 and 4 (each within the scatter of the next).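

Among the compounds shown here, the group on the saturated ring carbon of the shared core, which no earlier step had touched, turns out to matter in this assay: with the benzylsulfanyl group unchanged, 4-nitrophenyl in place of 3,4-dimethoxyphenyl gives a number 20.5 percentage points higher from compound 1 to compound 4 (beyond the scatter). For the compounds shown here, the number therefore responds to this position as well as to chloro on the aromatic ring of the benzylsulfanyl group, and this change gives a direction for the position that the earlier compounds could not supply. No measurement here accounts for the rise.

The single step swaps two methoxy groups for one nitro group, so the compounds shown cannot tell whether losing the methoxy groups or gaining the nitro group moves the number, a question that a plain phenyl or a 4-methoxyphenyl on this carbon would help to separate. Also open, as far as these compounds go, is whether chloro on the benzylsulfanyl group would raise the number further when 4-nitrophenyl sits on the saturated ring carbon.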